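This account rests on a few compounds, and the source may have more. Where it says the series, first, only, none or still open, it means among the compounds named here.

Measured so far:
Compound 1 `COc1cc(-c2nn(-c3cccc(NC(=O)Nc4cc(C(F)(F)F)cc(C(F)(F)F)c4)c3)cc2-c2ccncc2)ccc1Cl` gives > 50000 nM in a functional assay on SF-268 cells (Homo sapiens) for inhibition, read by sulforhodamine B assay, with a stated time of 48 h (a lower number here means that less compound is tolerated, a higher number that more compound is tolerated), a limit of the assay and not a number.
Compound 2 `O=C(Nc1cccc(-n2cc(-c3ccncc3)c(-c3ccc(Cl)c(O)c3)n2)c1)Nc1cc(C(F)(F)F)cc(C(F)(F)F)c1` gives 20500 nM in this assay.
Compound 3 `COc1cc(-c2nn(-c3cccc(NC(=O)Nc4ccc(Cl)c(C(F)(F)F)c4)c3)cc2-c2ccncc2)ccc1Cl` gives > 32500 nM in this assay, again a limit of the assay and not a number.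

Compound 1 and compound 2 share one core and differ by hydrogen in place of methyl on an oxygen on an aromatic ring. That change produced an at least 2.4-fold lower number from compound 1 to compound 2 (0.38 log units; beyond the scatter); the step is stated only as a bound because compound 1 sits at the limit of > 50000 nM in this assay, at which 1 of the 3 values shown sits. Compound 3 carries a different core; the difference between the two cores is not broken down here. Compound 4 `O=C(Nc1cccc(-n2cc(-c3ccncc3)c(-c3ccc(Cl)c(O)c3)n2)c1)Nc1ccc(Cl)c(C(F)(F)F)c1` is not yet measured and stands to compound 3 as compound 2 stands to compound 1, differing by hydrogen in place of methyl on an oxygen on an aromatic ring. The place of the change is the same in both pairs, so this is the same change, made a second time. Compound 3 itself sits at the limit of > 32500 nM in this assay, at which 1 of the 3 values shown sits, so the starting point for the second instance is, as with the first, a limit rather than a number.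

For compound 4 the expectation in this assay is a step of about the size seen in the first pair, an at least 1.8-fold lower number from compound 3 to compound 4 (0.25 log units; that floor lies within the scatter), resting on the earlier step from compound 1 to compound 2, which ended at 20500 nM for compound 2. Compound 4 is therefore estimated at 18000 nM, with a plausible range from 7000 nM to 50000 nM, while a reported limit instead of a number remains a real possibility.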

Compound 4, concentration lethal to 50% of the cells: > 32500 nM
Compound 4: no number, only a limit (the forecaster's own chance of this, stated with the estimate: 35%); middle value at least 1.8-fold (0.25 log units) from the limit.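

In this assay, going by these compounds alone, compound 3 and compound 4 both stand at a limit of the assay and not at a number, so no step between them can be read for the change from methoxy to hydroxy. The compounds shown leave open whether this change, which gave a lower number from compound 1 to compound 2, does the same on the core of compound 3.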